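This account rests on a few compounds, and the source may have more. Where it says the series, first, only, none or still open, it means among the compounds named here.

Working notes on the series. Among the measured compounds shown here, compound 1 `Cc1ccccc1-n1nc(-c2ccccc2)nc1CNc1ccc(C(=O)NO)cc1` gives 57.1% in an assay on Sf9 cells for inhibition of protein deacetylase HDAC6 (Homo sapiens), read by fluorescence, with a stated time of 40 min, tested at 100 nM (a higher number here means more inhibition at the concentration tested (going by the name of the read-out), a lower number less inhibition), and compound 2 `O=C(NO)c1ccc(NCc2nc(-c3ccccc3)nn2-c2ccc(Br)cc2)cc1` gives 65.9%; the only step measured so far, a number 8.8 percentage points higher from compound 1 to compound 2 (within the scatter), shows that the group on the aromatic nitrogen changes little. Compound 3 `Nc1ccccc1NC(=O)c1ccc(NCc2nc(-c3ccccc3)nn2-c2ccccc2)cc1` gives 5%, the lowest of the three numbers, standing well below compound 1 and further still below compound 2. Compound 4 `O=C(NO)c1ccc(NCc2nc(-c3ccccc3)nn2-c2ccccc2)cc1` differs from compound 3 at the amide end: hydroxy in place of 2-aminophenyl on an amide-type nitrogen.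

For the measured compounds named here, no measured step covers this change directly. What bears on it is that compound 1 and compound 2, which both carry the hydroxycarbamoyl group, sit far above compound 3, which carries the (2-aminophenyl)carbamoyl group; the step from compound 1 to compound 2 also suggests that the unsubstituted phenyl on the aromatic nitrogen of compound 4 should not move the number much from those two. A large upward step is therefore expected, a number 53 percentage points higher from compound 3 to compound 4 (beyond the scatter). Compound 4 is estimated at 58%, in the range 40% to 76%.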

Compound 4, a percentage reported as inhibition, at one concentration (the size of the read-out at that concentration, not a potency): 72.6%
Compound 4: the middle estimate sits 14.6 percentage points below what was measured, and the stated range covers the measured number.
By their numbers in this assay, from the lowest: compound 3; then compounds 1, 2 and 4 (each within the scatter of the next, the first and the last beyond it).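

The comparison with the largest step in the series, a number 67.6 percentage points higher from compound 3 to compound 4 (beyond the scatter) in this assay, ties the loss to this one place: with the core unchanged, hydroxy on the amide-type nitrogen goes with far more inhibition at the concentration tested than 2-aminophenyl. The substituent on the phenyl ring of the aromatic nitrogen matters less, though not uniformly: a number 6.7 percentage points higher from compound 2 to compound 4 (within the scatter) for hydrogen in place of bromo stays within the scatter, while a number 15.5 percentage points higher from compound 1 to compound 4 (beyond the scatter) for hydrogen in place of methyl is a modest step beyond it. Nothing available explains either effect.

The compounds shown leave open how an amine or a methoxy group on the amide-type nitrogen would compare with hydroxy. They also leave open how a carboxylic acid would read in place of the hydroxycarbamoyl group.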